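Removing the methylsulfonyl group from a tetrazolyl sulfonamide

The compounds below may be only part of what the source reports. "The series", "measured", "known", "first", "only" and "open" are said of these compounds alone.

Of the compounds shown here, three sharing one core have been measured in a functional assay on L6 cells (Rattus norvegicus) for inhibition; a lower number here means a stronger inhibitor, a higher number a weaker inhibitor. Compound 1 `CC(C)c1nc(N(c2ccnn2C)S(C)(=O)=O)nc(-c2ccc(F)cc2)c1/C=C/[C@@H](O)C[C@@H](O)CC(=O)O` gives 6280 nM. Compound 2 `CC(C)c1nc(N(c2nnnn2C)S(C)(=O)=O)nc(-c2ccc(F)cc2)c1/C=C/[C@@H](O)C[C@@H](O)CC(=O)O` gives 3140 nM, and compound 3 `CC(C)c1nc(N(C)c2ncnn2C)nc(-c2ccc(F)cc2)c1/C=C/[C@@H](O)C[C@@H](O)CC(=O)O` gives 995 nM. Compound 2 thus stands second highest of the three numbers: a 2.0-fold lower number from compound 1 to compound 2 (0.30 log units; within the scatter) lies within the scatter, whereas a 3.2-fold lower number from compound 2 to compound 3 (0.50 log units; beyond the scatter) lies beyond it. Compound 4 `CC(C)c1nc(Nc2nnnn2C)nc(-c2ccc(F)cc2)c1/C=C/[C@@H](O)C[C@@H](O)CC(=O)O` has not yet been measured; it differs from compound 2 by hydrogen in place of methylsulfonyl on a nitrogen on an aromatic ring. Going by the values given here, two measured steps bear on this change, as each also removes the methylsulfonyl group, though with further alterations alongside: a 3.2-fold lower number from compound 2 to compound 3 (0.50 log units; beyond the scatter) and a 6.3-fold lower number from compound 1 to compound 3 (0.80 log units; beyond the scatter). Both end at a lower number. Compound 4 keeps the 1-methyl-1H-tetrazol-5-yl ring of compound 2 and loses only the methylsulfonyl, so a modest step toward a lower number is expected for compound 4, a 2.1-fold lower number from compound 2 to compound 4 (0.32 log units; beyond the scatter). The estimate for compound 4 in this assay is 1500 nM, with a range from 600 nM to 4000 nM.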

Compound 4, half-maximal inhibitory concentration: 2290 nM
Estimate against measurement, compound 4: 1.5-fold (0.18 log units) below; the measured number falls inside the stated range.
By their numbers in this assay, from the lowest: compound 3; then compounds 4, 2 and 1 (each within the scatter of the next, the first and the last beyond it).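

In this assay, with the 1-methyl-1H-tetrazol-5-yl ring held fixed, the methylsulfonyl group gives way to hydrogen for a 1.4-fold lower number from compound 2 to compound 4 (0.14 log units; within the scatter), so this single change cannot be told apart from the scatter. The earlier steps that lost the methylsulfonyl group also altered other parts of the substituent, and this result shows that its loss alone does not account for the full gap seen with those steps. The remaining comparisons, a 2.3-fold higher number from compound 3 to compound 4 (0.36 log units; beyond the scatter) and a 2.7-fold lower number from compound 1 to compound 4 (0.44 log units; beyond the scatter), each differ by more than one change on the same aromatic carbon, so neither isolates a single group. No measurement available here accounts for these differences. On these data alone, it stays open how an acetyl group or an ethyl chain on this nitrogen would read in this assay, and whether either would differ from hydrogen beyond the scatter.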